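This account rests on a few compounds, and the source may have more. Where it says the series, first, only, none or still open, it means among the compounds named here.

Compound 2 `CCC/N=C1\S/C(=C\c2ccc(O)c(Cl)c2)C(=O)N1c1ccccc1OC` carries a 2-methoxyphenyl on the amide-type ring nitrogen of the shared core, and in a physicochemical assay for solubility, measured as kinetic solubility (a lower number here means a less soluble compound, a higher number a more soluble compound), compound 2 gives 79000 nM. It stands level with compound 1 `CCC/N=C1\S/C(=C\c2ccc(O)c(Cl)c2)C(=O)N1C1CC1`, which in this assay gives 79000 nM; the step of no change at the digits printed from compound 1 to compound 2 (within the scatter) lies within the scatter, so the exchange of cyclopropyl for 2-methoxyphenyl at that nitrogen left the read-out unmoved.

Compound 3 `CCC/N=C1\S/C(=C\c2ccc(O)c(Cl)c2)C(=O)N1C(C)C` is the next variation at the same position: isopropyl in place of 2-methoxyphenyl on an amide-type nitrogen in a ring. Among the compounds with values here, the only step that bears on it is no change at the digits printed from compound 1 to compound 2 (within the scatter), which showed that two quite different groups on this nitrogen give the same solubility. Isopropyl is another such group, and no measured step points to a shift in either direction, so the expected step of no change at the digits printed from compound 2 to compound 3 (within the scatter) in this assay is none beyond the scatter. Compound 3 is therefore estimated at 79000 nM, with a range from 40000 nM to 160000 nM.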

Compound 3, solubility: 20000 nM
Compound 3: the middle estimate sits 4.0-fold (0.60 log units) above what was measured, and the stated range ends above it.
By their numbers in this assay, from the lowest: compound 3; then compounds 1 and 2 (each within the scatter of the next).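

In this assay the ring nitrogen is no longer a silent position: isopropyl gives a 4.0-fold lower number from compound 2 to compound 3 (0.60 log units; beyond the scatter) and a 4.0-fold lower number from compound 1 to compound 3 (0.60 log units; beyond the scatter), so the two level compounds did not show that this nitrogen tolerates any group. Among these three compounds, the two groups that carry a ring, cyclopropyl and 2-methoxyphenyl, read level, and the ring-free isopropyl reads lower, with none of the three going against that pattern. Nothing on hand gives a reason for this step.

On these data alone, whether the lower reading goes with ring-free groups in general stays open, and a straight propyl chain or a tert-butyl group on this nitrogen would test that. Also open, as far as these compounds go, is how a group bearing an amine or a carboxylic acid would read at this position.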